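Trifluoromethyl in place of fluoro on compound 2

The source may hold more compounds than are shown below. What is called first, only, known or untested is meant among the compounds shown, and "the series" means these compounds.

Compound 1 `Fc1cc(Cl)ccc1-c1ccc(Cn2nnc3ccccc32)cc1` gives 28 nM in a functional assay on cells for positive allosteric modulation of metabotropic glutamate receptor 2 (Homo sapiens), read by fluorescence and calcium flux, with a stated time of 30 min; a lower number here means that less compound is needed, a higher number that more compound is needed for the effect. Compound 2 `Fc1ccc(-c2ccc(Cn3nnc4ccccc43)cc2)c(Cl)c1` gives 118 nM in this assay, the higher of the two numbers measured. Among the measured compounds shown here, the single measured step is a 4.2-fold higher number from compound 1 to compound 2 (0.62 log units; beyond the scatter). Compound 3 `FC(F)(F)c1ccc(-c2ccc(Cn3nnc4ccccc43)cc2)c(Cl)c1` carries trifluoromethyl in place of fluoro on an aromatic carbon, placed meta to a chloro group and para to a large group. For the measured compounds named here, no measured step exchanges fluoro for trifluoromethyl; the one step available swaps halogen positions and bears only loosely here. The step expected is therefore small, a 1.2-fold lower number from compound 2 to compound 3 (0.07 log units; within the scatter), likely within the scatter. Compound 3 is estimated at 100 nM, with a range from 30 nM to 350 nM.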

Compound 3, half-maximal effective concentration: 37 nM
Estimate against measurement, compound 3: 2.7-fold (0.43 log units) above; low and high end bracket the measured number.
By their numbers in this assay, from the lowest: compounds 1 and 3 (each within the scatter of the next); then compound 2.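

In this assay, trifluoromethyl in place of fluoro gives a 3.2-fold lower number from compound 2 to compound 3 (0.50 log units; beyond the scatter). The earlier compounds shown here showed only an exchange of halogen positions; here, on an aromatic carbon meta to a chloro group and para to a large group, a group of 4 heavy atoms replaces a single atom and the number falls beyond the scatter. This position therefore accepts more than a lone halogen.

From the compounds shown here alone, whether that holds for other groups stays open, and a methyl, methoxy or nitrile at this place would test it. No evidence at hand explains this step.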